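This account rests on a few compounds, and the source may have more. Where it says the series, first, only, none or still open, it means among the compounds named here.

Values in a functional assay on MCF7 cells (Homo sapiens) for cytotoxicity, read by MTT assay, with a stated time of 72 h; a lower number here means a stronger inhibitor, a higher number a weaker inhibitor:
- Compound 1 `CN(C)c1ccc(C=C2C(=O)N(c3ccc(Cl)cc3)N(c3ccc(Cl)cc3)C2=O)cc1`: > 128000 nM (a limit, not a number)
- Compound 2 `O=C1C(=Cc2cccc(Cl)c2)C(=O)N(c2ccc(Cl)cc2)N1c1ccc(Cl)cc1`: 18300 nM
- Compound 3 `O=C1C(=Cc2ccco2)C(=O)N(c2ccc(Cl)cc2)N1c1ccc(Cl)cc1`: 20300 nM

Compound 3 stands level with compound 2 in this assay, since the step of a 1.1-fold higher number from compound 2 to compound 3 (0.05 log units; within the scatter) lies within the scatter. The next compound, compound 4 `O=C1C(=Cc2c[nH]c3ccccc23)C(=O)N(c2ccc(Cl)cc2)N1c1ccc(Cl)cc1`, keeps the shared core and changes one group: 1H-indol-3-yl in place of furan-2-yl on a double-bonded chain carbon bound to a double-bonded ring carbon. Here 1H-indol-3-yl stands in place of furan-2-yl on a double-bonded chain carbon bound to a double-bonded ring carbon.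

Among the compounds with values here, three measured steps bear on this change, all at that same place. Replacing 3-chlorophenyl with furan-2-yl made no difference beyond the scatter, so those two groups do not separate. Compound 1, which carries 4-(dimethylamino)phenyl, goes against any idea that the group here is immaterial: the steps of an at least 6.9-fold lower number from compound 1 to compound 2 (0.84 log units; beyond the scatter) and an at least 6.3-fold lower number from compound 1 to compound 3 (0.79 log units; beyond the scatter) are both beyond the scatter, and both are known only as bounds. Within the data shown here, no measured compound carries 1H-indol-3-yl, so neither direction can be favoured with confidence, although a weaker result remains possible, as compound 1 shows.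

The expected step is a 1.0-fold higher number from compound 3 to compound 4 (0.01 log units; within the scatter), which means no change beyond the scatter is expected. For compound 4 the estimated value is 21000 nM, with an expected range from 6500 nM to 70000 nM.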

Compound 4, half-maximal inhibitory concentration: 34200 nM
Compound 4: middle estimate off by 1.6-fold (0.21 log units), on the low side; the range from low to high includes it.
By their numbers in this assay, from the lowest: compounds 2, 3 and 4 (each within the scatter of the next). At a limit, above all of these: compound 1.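

In this assay, the larger 1H-indol-3-yl group, with its added six-membered aromatic ring of carbon only and a hydrogen-bond donor, does not separate from the smaller groups at this place: a 1.7-fold higher number from compound 3 to compound 4 (0.23 log units; within the scatter) and a 1.9-fold higher number from compound 2 to compound 4 (0.27 log units; within the scatter) both stay within the scatter. Three quite different groups on the double-bonded chain carbon, namely 3-chlorophenyl, furan-2-yl and 1H-indol-3-yl, therefore cannot be told apart, and the added ring and the change of hetero atom bring no measurable change here. Only 4-(dimethylamino)phenyl goes against this, with an at least 3.7-fold lower number from compound 1 to compound 4 (0.57 log units; beyond the scatter) beyond the scatter, and that step is only a bound, as compound 1 stands at a limit, not a number: the limit of > 128000 nM in this assay, at which 1 of the 4 values shown sits.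

The compounds shown leave open whether the dimethylamino group itself sets compound 1 apart, which a 4-methoxyphenyl or a 3-(dimethylamino)phenyl group at this place would help to settle. They also leave open whether the hydrogen on the indole nitrogen matters, as a 1-methylindol-3-yl group would show, and whether any group here, such as a carboxylic acid, gives a clearly lower number.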